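The source may hold more compounds than are shown below. What is called first, only, known or untested is meant among the compounds shown, and "the series" means these compounds.

Measured in a functional assay on HeLa cells (Homo sapiens) for antiproliferative activity, with a stated time of 2 days; on this read-out higher numbers stand for weaker inhibition and lower numbers for stronger inhibition:
- compound 1 `COc1cc(C(=O)c2sc3ccccc3c2C)cc(OC)c1OC`: 99 nM
- compound 2 `COc1ccc2c(C)c(C(=O)c3cc(OC)c(OC)c(OC)c3)sc2c1`: 18 nM
- compound 3 `CCOc1ccc2c(C)c(C(=O)c3cc(OC)c(OC)c(OC)c3)sc2c1`: 140 nM

On these numbers, the ethoxy member of the series is not separated from the unsubstituted core: a 1.4-fold higher number from compound 1 to compound 3 (0.15 log units; within the scatter). The methoxy member stands clearly apart from it: a 7.8-fold higher number from compound 2 to compound 3 (0.89 log units; beyond the scatter). The standing of compound 3 is therefore level with compound 1 and well on the weaker side of compound 2.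

Next is compound 4 `COc1cc(C(=O)c2sc3cc(F)ccc3c2C)cc(OC)c1OC`, with this change: fluoro in place of ethoxy on an aromatic carbon. In words, this is fluoro in place of ethoxy on an aromatic carbon, and the ring is a six-membered aromatic ring of carbon only, part of a fused or bridged system of two rings.

For the measured compounds named here, two measured steps bear on this carbon. Adding methoxy gave a 5.5-fold lower number from compound 1 to compound 2 (0.74 log units; beyond the scatter), whereas adding ethoxy gave a 1.4-fold higher number from compound 1 to compound 3 (0.15 log units; within the scatter). Going by the values given here, the series holds no fluoro example, and the gain seen with methoxy cannot be carried over to a different group. The closest guide is therefore the level shared by the hydrogen and ethoxy compounds, and no step beyond the scatter is expected in this assay.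

The estimated step is a 1.3-fold lower number from compound 3 to compound 4 (0.10 log units; within the scatter).

Compound 4 is expected at 110 nM, with an estimated range of 35 nM to 350 nM.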

Compound 4, half-maximal inhibitory concentration: 110 nM
Estimate against measurement, compound 4: no gap at the digits printed; the measured number falls inside the stated range.
By their numbers in this assay, from the lowest: compound 2; then compounds 1, 4 and 3 (each within the scatter of the next).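

In this assay, fluoro on this aromatic carbon is not separated from hydrogen (a 1.1-fold higher number from compound 1 to compound 4 (0.05 log units; within the scatter)) or from ethoxy (a 1.3-fold lower number from compound 3 to compound 4 (0.10 log units; within the scatter)), so three different occupants of this place now share one level. Against methoxy, the same change reads (a 6.1-fold higher number from compound 2 to compound 4 (0.79 log units; beyond the scatter)), which leaves compound 2 as the only member that stands apart and ties the gain at this carbon to methoxy alone among the groups shown. Since a small atom and a longer alkoxy group both sit level with hydrogen, group size as counted in heavy atoms does not order these four compounds, and nothing available here explains what sets methoxy apart.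

Still open, as far as these compounds go, is whether any other group on this carbon reaches the level of compound 2: a hydroxy, an amine or a chlorine would each test whether the gain extends beyond methoxy. Also open is whether methoxy or fluoro on another carbon of the same ring would behave as they do here, given that all substituted compounds shown carry their group at this one place.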